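The compounds below may be only part of what the source reports. "The series", "measured", "known", "first", "only" and "open" are said of these compounds alone.

Series notes in a functional assay for antagonist activity at Alpha-1A adrenergic receptor (Oryctolagus cuniculus); on this read-out higher numbers stand for weaker binding and lower numbers for tighter binding:

- compound 1, `COc1ccccc1N1CCN(CCCNc2ncccc2C(=O)N(C)C)CC1`, gives 1.59 nM
- compound 2, `CN(C)C(=O)c1cccnc1NCCCN1CCN(c2ccccc2-c2ncco2)CC1`, gives 0.316 nM
- compound 3, `COc1cc(F)ccc1N1CCN(CCCNc2c(C(=O)N(C)C)cnc3c2c(C)nn3C)CC1`, gives 1.26 nM

Compound 2 differs from compound 1 by 1,3-oxazol-2-yl in place of methoxy on an aromatic carbon. That single change brings a 5.0-fold lower number from compound 1 to compound 2 (0.70 log units; beyond the scatter). Compound 3 carries a different core from compound 1; the difference between the two cores is not broken down here. The values of compound 3 and compound 1 lie within the scatter of each other, so no order between them is claimed; the gap from compound 3 to compound 2 lies beyond the scatter.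

Compound 4, `Cc1nn(C)c2ncc(C(=O)N(C)C)c(NCCCN3CCN(c4ccc(F)cc4-c4ncco4)CC3)c12`, has not been measured. It differs from compound 3 by 1,3-oxazol-2-yl in place of methoxy on an aromatic carbon. Among the compounds with values here, this is the same kind of change as the one from compound 1 to compound 2, not the same change: in compound 1 the place is ortho to a large group only, while in compound 3 it is ortho to a large group and meta to a fluoro group, and the core is the other one. Read one bond further out it is 4-fluoro-2-methoxyphenyl to 4-fluoro-2-(1,3-oxazol-2-yl)phenyl.

For compound 4 the expected step is a 3.9-fold lower number from compound 3 to compound 4 (0.60 log units; beyond the scatter), set somewhat short of the precedent because a 5.0-fold lower number from compound 1 to compound 2 (0.70 log units; beyond the scatter) rests on one pair in a different core. Compound 4 is estimated at 0.32 nM in this assay, with an expected range from 0.12 nM to 0.9 nM.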

Compound 4, dissociation constant: 0.126 nM
For compound 4 the middle estimate is 2.5-fold (0.40 log units) above the measured one, and the stated range covers the measured number.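

In this assay, putting 1,3-oxazol-2-yl in place of methoxy on the core of compound 3 gives a 10-fold lower number from compound 3 to compound 4 (1.00 log units; beyond the scatter), which runs in the same direction as the earlier step on the core of compound 1 and is likewise beyond the scatter. On these two pairs the change carries from one core to the other, with no difference in size that can be claimed between the steps: the same change on two cores in this assay, a 5.0-fold lower number (0.70 log units; beyond the scatter) from compound 1 to compound 2 and a 10-fold lower number (1.00 log units; beyond the scatter) from compound 3 to compound 4, 2.0-fold (0.30 log units) apart, within the scatter of two such steps

Within the data shown here, this does not show that the core has no influence on the step, nor does it set a rule for any core beyond these two, as two pairs are a thin basis and the second pair also carries a fluoro group on the aromatic ring, so any small effect of the core or of that group would go unseen here.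

Open, as far as these compounds go, is whether the gain extends to other groups in the same place, such as 1,3-thiazol-2-yl, ethoxy or a nitrile, and whether it persists with a longer chain linking the two halves of the molecule. Also open, from the compounds shown here alone, is what the fluoro group contributes by itself, which only a pair differing in that group alone on one shared core could settle.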